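The source may hold more compounds than are shown below. What is called first, only, known or untested is meant among the compounds shown, and "the series" means these compounds.

Compound 1 `CNC(=O)c1cc(Oc2ccc3nc(Nc4cccc(C(C)(C)C)c4)ccc3c2)ccn1` gives < 1 10^-6 cm/s in an ADME assay on Caco-2 cells (Homo sapiens) for permeability, in the apical to basolateral direction (a lower number here means that the compound crosses the layer more slowly, a higher number that the compound crosses the layer faster), which is a limit of the assay.
Compound 2 `CCc1ccccc1Nc1ncc2cc(Oc3ccnc(C(=O)NC)c3)ccc2n1` gives < 1 10^-6 cm/s in this assay, again a limit.
Compound 3 `CNC(=O)c1cc(Oc2ccc3nc(Nc4cccc(Cl)c4)ncc3c2)ccn1` gives < 1 10^-6 cm/s in this assay, also a limit.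

All three measured compounds sit at the same limit of this assay, as the limit of < 1 10^-6 cm/s in this assay, at which 3 of the 3 values shown sit, records, so compound 3 has no number of its own, only that limit. Among the compounds with values here, the one comparable step, a step that the two limits leave unreadable from compound 2 to compound 3, cannot be read because both of its ends are limits. Compound 4 `CNC(=O)c1cc(Oc2ccc3nc(Nc4ccc(C(F)(F)F)cc4)ncc3c2)ccn1` differs from compound 3 by 4-(trifluoromethyl)phenyl in place of 3-chlorophenyl on a nitrogen on an aromatic ring. Within the data shown here, no measured step bears on this change with a readable size, and nothing among the three values separates any compound from the others. The expectation for compound 4 in this assay is therefore that the step that the limit leaves unreadable from compound 3 to compound 4 stays within the scatter and that the value again comes out at the limit. Compound 4 is estimated at 0.5 10^-6 cm/s, with a range from 0.2 10^-6 cm/s to 1.5 10^-6 cm/s.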

Compound 4, apparent permeability: < 1 10^-6 cm/s
Compound 4: a limit, no number; the forecaster's own chance of this, stated with the estimate: 80%; the middle value is on the limit's open side.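

Compound 4 gives only a limit in this assay, as do compound 2 and compound 3, so neither step to compound 4 can be read. The compounds shown leave open how any of them truly compares with the others, as all share one limit: the limit of < 1 10^-6 cm/s in this assay, at which 4 of the 4 values shown sit.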